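The source may report more compounds than this note shows. Statements on the series, on what has been measured and on what is new or still open speak of the compounds shown alone.

Measured in a functional assay on HeLa cells (Homo sapiens) for antiproliferative activity, read by MTT assay, with a stated time of 48 h (on this read-out lower numbers stand for stronger inhibition and higher numbers for weaker inhibition), so far
Compound 1 `COc1ccc(-c2nc3cnccc3n2-c2cc(OC)c(OC)c(OC)c2)cc1O` gives > 20000 nM
Compound 2 `COc1ccc(-c2cc3c(cn2)[nH]c(=O)n3-c2cc(OC)c(OC)c(OC)c2)cc1C` gives 1410 nM
Compound 3 `COc1ccc(-c2cc3c(cn2)n(C)c(=O)n3-c2cc(OC)c(OC)c(OC)c2)cc1O` gives 2220 nM

The entry for compound 1 is a limit of the assay and not a number. Going by the values given here, compound 2 at 1410 nM and compound 3 at 2220 nM lie within the scatter of each other, so compound 3 stands level with the only other number available. Compound 4 `COc1ccc(-c2cc3c(cn2)n(CC(N)=O)c(=O)n3-c2cc(OC)c(OC)c(OC)c2)cc1O` carries carbamoyl in place of hydrogen on a saturated chain carbon bound to an aromatic nitrogen (methyl to carbamoylmethyl). Among the compounds with values here, no measured pair isolates this change, so in this assay no step beyond the scatter is expected. The estimate is a 1.6-fold higher number from compound 3 to compound 4 (0.20 log units; within the scatter) and it leans toward weaker inhibition. For compound 4 the expected value is 3500 nM (estimated range 1000 nM to 12000 nM).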

Compound 4, half-maximal inhibitory concentration: > 20000 nM
Compound 4 ended at the assay's limit; the forecaster's own chance of this, stated with the estimate: 15%; middle value at least 5.7-fold (0.75 log units) from the limit.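

Carbamoyl in place of hydrogen on a saturated chain carbon bound to an aromatic nitrogen brings an at least 9.0-fold higher number from compound 3 to compound 4 (0.95 log units; beyond the scatter) in this assay, the first step beyond the scatter that isolates a single change. Going by these compounds alone, this place on the shared core therefore does not accept every group, which no earlier pair could show. Going by these compounds, the true size of the step stays unknown, since compound 4 sits at a limit of the assay and not at a number: the limit of > 20000 nM in this assay, at which 2 of the 4 values shown sit.

On these data alone, whether a longer chain, an amine or a carboxylic acid at this place would stay level with compound 3 remains open.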